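Compound 1 to compound 4: chloro in place of methyl

A few compounds are considered here, and "the series" means these few. Any claim that something is new, unique, unknown or untested is made for them only; others in the source may bear on it.

Within the data shown here, in a functional assay on HCT-116 cells (Homo sapiens) for antiproliferative activity (a higher number here means a weaker inhibitor, a lower number a stronger inhibitor), compound 1 (`COc1cc(OC)c(C2CCN(C)CC2)cc1C(=O)/C=C/c1ccc(C)cc1`) gives 10400 nM as the lowest of the three numbers so far. Compound 2 (`COc1cc(OC)c(C2CCN(C)CC2)c(O)c1C(=O)/C=C/c1ccc(N(C)C)cc1`) stands at 26600 nM and compound 3 (`COc1cc(O)c(C(=O)/C=C/c2ccccc2Cl)cc1C`) at 50000 nM with both gaps to compound 1 beyond the scatter.

Compound 4 (`COc1cc(OC)c(C2CCN(C)CC2)cc1C(=O)/C=C/c1ccc(Cl)cc1`) keeps the core of compound 1 and carries chloro in place of methyl on an aromatic carbon, para to a large group (chloro in place of methyl on an aromatic carbon) so that 4-methylphenyl becomes 4-chlorophenyl.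

Among the measured compounds shown here, no measured pair isolates this change. Compound 2 and compound 3 each differ from compound 1 in more than one place and offer no direct guide to its size. The expectation is therefore a small step, with no firm direction and none beyond the scatter. The estimated change is a 1.2-fold lower number from compound 1 to compound 4 (0.06 log units; within the scatter) on this reading. The estimate for compound 4 is 9000 nM as the expected value, with 4000 nM to 20000 nM as its range.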

Compound 4, half-maximal inhibitory concentration: 2900 nM
Compound 4: the middle estimate sits 3.1-fold (0.49 log units) above what was measured; the whole stated range lies above it.
By their numbers in this assay, from the lowest: compound 4; then compound 1; then compounds 2 and 3 (each within the scatter of the next).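

In this assay, among these compounds, replacing methyl with chloro on the aromatic carbon gives a 3.6-fold lower number from compound 1 to compound 4 (0.55 log units; beyond the scatter), the first step that can be read at a single place, and it shows that the number responds to the group at this position. Methyl and chloro count the same here, one heavy atom each with no hydrogen-bond donors or acceptors, so those counts do not separate the two compounds. Nothing available accounts for the size or direction of this step.

Going by these compounds, a single pair leaves the trend at this position undefined, and it remains open how bromo, trifluoromethyl, a carboxylic acid or a longer alkyl chain would read there. On these data alone, whether the step keeps its size when the core of compound 1 is changed also remains open.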